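Solubility notes: cyclopentyl to cyclopropyl on the shared core

The compounds below may be only part of what the source reports. "The series", "measured", "known", "first", "only" and "open" are said of these compounds alone.

Compound 1 `Fc1ccc(-c2nc3cnc(Nc4ccccn4)cc3[nH]2)cc1F`: < 5000 nM, a limit
Compound 2 `FC(F)(F)c1cccc(-c2nc3cnc(Nc4ccc(-c5nnn[nH]5)cn4)cc3[nH]2)c1`: < 5000 nM, a limit
Compound 3 `FC(F)(F)c1ccc(Nc2cc3[nH]c(C4CCCC4)nc3cn2)nc1`: 145000 nM

All values come from a physicochemical assay for solubility, using the shake flask method, in phosphate buffer, measured as kinetic solubility, with a stated time of 20 h, at pH 6.5; on this read-out lower numbers stand for lower solubility and higher numbers for higher solubility. Within the data shown here, the series so far is bounded by the limit of < 5000 nM in this assay, at which 2 of the 3 values shown sit. Among the measured compounds shown here, compound 3 holds the only actual number, 145000 nM.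

Compound 4 `FC(F)(F)c1ccc(Nc2cc3[nH]c(C4CC4)nc3cn2)nc1` has not yet been measured. It carries cyclopropyl in place of cyclopentyl on an aromatic carbon. For the measured compounds named here, no measured pair isolates this change, so only a slight rise is expected, with no step beyond the scatter: the expected move is a 1.3-fold higher number from compound 3 to compound 4 (0.12 log units; within the scatter). The estimated value for compound 4 is 190000 nM, within an expected range of 60000 nM to 450000 nM.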

Compound 4, solubility: < 5000 nM
Compound 4: only a limit was reported; the forecaster's own chance of this, stated with the estimate: 10%; at least 38-fold (1.57 log units) between middle value and limit.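

Among these compounds, the first step falls on the aromatic carbon between two ring nitrogen atoms: in this assay, cyclopropyl in place of cyclopentyl gives an at least 29-fold lower number from compound 3 to compound 4 (1.46 log units; beyond the scatter). Compound 4 reads < 5000 nM, which is a limit. Compound 3 is now the only compound with an actual number: the limit of < 5000 nM in this assay, at which 3 of the 4 values shown sit.

As far as these compounds go, whether ring size alone governs the number at this place stays open, with only cyclopentyl and cyclopropyl to compare. A cyclobutyl ring, a longer chain or an amine on the same carbon would test this.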